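The source may report more compounds than this note shows. Statements on the series, on what has been measured and on what is new or still open speak of the compounds shown alone.

In an assay on Sf9 cells for inhibition of Leucine-rich repeat serine/threonine-protein kinase 2 (Homo sapiens), read by TR-FRET, with stated times of 30 min and 2 h (a higher number here means a weaker inhibitor, a lower number a stronger inhibitor), compound 1 `O=C(Nc1ccnnc1)c1cc(C(F)(F)F)ccc1OCc1ccccc1` gives 15.9 nM, and compound 2 `O=C(Nc1cccc(Cl)c1)c1cc(C(F)(F)F)ccc1OCc1ccccc1` gives 25.1 nM. For the measured compounds named here, compound 2 holds the higher of the two numbers known so far, yet its only neighbour is compound 1, and the step of a 1.6-fold higher number from compound 1 to compound 2 (0.20 log units; within the scatter) stays within the scatter, so the two cannot be told apart on these numbers. Compound 3 `O=C(Nc1cccnc1)c1cc(C(F)(F)F)ccc1OCc1ccccc1` has not yet been measured. It differs from compound 2 in one place: pyridin-3-yl in place of 3-chlorophenyl on an amide-type nitrogen. Going by the values given here, only one measured step bears on this change, the earlier exchange of pyridazin-4-yl for 3-chlorophenyl on the same amide-type nitrogen, and that step, a 1.6-fold higher number from compound 1 to compound 2 (0.20 log units; within the scatter), did not reach beyond the scatter. Pyridin-3-yl, like pyridazin-4-yl, is a six-membered aromatic ring with a hetero atom and a hydrogen-bond acceptor, so the present change partly undoes the earlier one. The step of a 1.4-fold lower number from compound 2 to compound 3 (0.14 log units; within the scatter) that the estimate implies is therefore expected to be small, if anything toward a lower number, and not clearly beyond the scatter. Compound 3 is accordingly estimated at 18 nM, with a range from 8 nM to 40 nM.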

Compound 3, half-maximal inhibitory concentration in the Leucine-rich repeat serine/threonine-protein kinase 2 assay: 12.6 nM
Compound 3: middle estimate off by 1.4-fold (0.15 log units), on the high side; low and high end bracket the measured number.
By their numbers in the Leucine-rich repeat serine/threonine-protein kinase 2 assay, from the lowest: compounds 3, 1 and 2 (each within the scatter of the next).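

In the Leucine-rich repeat serine/threonine-protein kinase 2 assay, the new result adds a third ring on the amide-type nitrogen, and the numbers still do not separate the three: a 2.0-fold lower number from compound 2 to compound 3 (0.30 log units; within the scatter), and a 1.3-fold lower number from compound 1 to compound 3 (0.10 log units; within the scatter). For the compounds shown here, the earlier compounds showed only that one pair could not be told apart, so this position now accepts 3-chlorophenyl, pyridazin-4-yl and pyridin-3-yl with no difference that can be read in the Leucine-rich repeat serine/threonine-protein kinase 2 assay. What the same exchange does change is seen in a physicochemical assay for lipophilicity, at pH 7.4 (on this read-out higher numbers stand for higher lipophilicity and lower numbers for lower lipophilicity), where compound 2 gives 8.8 and compound 3 gives 6.3, and where pyridin-3-yl in place of 3-chlorophenyl brings a large fall in lipophilicity while the inhibition number stays within the scatter, so at this place the two properties can move apart: the measured distribution coefficient of compound 2, 8.8, and of compound 3, 6.3, a number 2.50 log units lower (beyond the scatter).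

As far as these compounds go, all three compounds carry a six-membered aromatic ring at this position, so it remains open whether a saturated ring such as piperidine, or a ring bearing an amine or a carboxylic acid, would keep the inhibition. From the compounds shown here alone, it also remains open whether the same freedom holds elsewhere on the shared core, for example with a nitrile in place of the trifluoromethyl group.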